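The source may hold more compounds than are shown below. What is called first, only, known or untested is meant among the compounds shown, and "the series" means these compounds.

Measured so far in an assay on HEK293 cells for positive allosteric modulation of metabotropic glutamate receptor 5 (Homo sapiens), read by FLIPR; on this read-out lower numbers stand for an effect already at smaller amounts and higher numbers for an effect only at larger amounts of compound:
compound 1 `O=C(N1CCCCC1)N1CC(c2nc(-c3cccc(Cl)c3)no2)C1` — 370 nM
compound 2 `O=C(c1ccc(F)c(F)c1)N1CC(c2nc(-c3cccc(F)c3)no2)C1` — 3200 nM
compound 3 `O=C(c1cccc(F)c1)N1CC(c2nc(-c3cccc(Cl)c3)no2)C1` — > 10000 nM

For compound 3 only a limit is known, namely (the limit of > 10000 nM in this assay, at which 1 of the 3 values shown sits); no number inside the measurable range was obtained. Compound 4 `CC1CCN(C(=O)N2CC(c3nc(-c4cccc(Cl)c4)no3)C2)CC1` differs from compound 3 by 4-methylpiperidin-1-yl in place of 3-fluorophenyl on a carbonyl carbon. Within the data shown here, one measured step bears on this change, and it runs the opposite way: an at least 27-fold higher number from compound 1 to compound 3 (1.43 log units; beyond the scatter), so the aryl amide of compound 3 gave a far higher number than the cyclic urea of compound 1. Compound 4 returns to a urea of that kind, now carrying 4-methylpiperidin-1-yl, so a large drop in the number is expected. For compound 4 the expected step is an at least 25-fold lower number from compound 3 to compound 4 (1.39 log units; beyond the scatter). Compound 4 is therefore estimated at 400 nM, within a range of 150 nM to 1200 nM.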

Compound 4, half-maximal effective concentration: 865 nM
For compound 4 the middle estimate is 2.2-fold (0.33 log units) below the measured one, within the range that was stated.
By their numbers in this assay, from the lowest: compound 1; then compound 4; then compound 2. At a limit, above all of these: compound 3.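

There is an at least 11-fold lower number from compound 3 to compound 4 (1.06 log units; beyond the scatter) in this assay and so a second urea, besides compound 1, gives a measured value where the aryl amide of compound 3 does not. Compound 3 is known only as a limit: the limit of > 10000 nM in this assay, at which 1 of the 4 values shown sits. Methyl on a saturated ring carbon of the urea is not neutral either: there is a 2.3-fold higher number from compound 1 to compound 4 (0.37 log units; beyond the scatter) in this single pair.

Going by these compounds, whether a hydroxyl or an amine on that ring carbon, or a morpholine in place of the piperidine, would give a lower number stays open.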